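Swapping Chloro for Methoxy on the Anilino Ring

A few compounds are considered here, and "the series" means these few. Any claim that something is new, unique, unknown or untested is made for them only; others in the source may bear on it.

Compound 1, `COc1ccc(N/C=C\C(=O)c2cn(-c3ccccc3)nc2-c2ccccc2)cc1`: > 50000 nM in a functional assay on U-87MG ATCC cells (Homo sapiens) for antiproliferative activity, read by MTT assay, with a stated time of 48 h (a lower number here means a stronger inhibitor, a higher number a weaker inhibitor), a limit of the assay, not a number.
Compound 2, `COc1ccc(N/C=C\C(=O)c2cn(-c3ccccc3)nc2-c2ccc(F)cc2)cc1`: 2500 nM.
Compound 3, `COc1cc(-c2nn(-c3ccccc3)cc2C(=O)/C=C\Nc2ccc(Cl)cc2)cc(OC)c1OC`: 3210 nM.

Within this assay, compound 3 carries the highest of the two real numbers, though its gap to compound 2 lies within the scatter. The only measured step among these compounds, an at least 20-fold lower number from compound 1 to compound 2 (1.30 log units; beyond the scatter), concerns the phenyl ring attached to the shared core, not the anilino ring; compound 1 itself stands at the limit of > 50000 nM in this assay, at which 1 of the 3 values shown sits.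

Compound 4, `COc1ccc(N/C=C\C(=O)c2cn(-c3ccccc3)nc2-c2cc(OC)c(OC)c(OC)c2)cc1`, differs from compound 3 by methoxy in place of chloro on an aromatic carbon. Among the compounds with values here, no measured step touches this position, so the direction and size of the change cannot be read from the data. Compound 4 is therefore expected to stay near compound 3, and the estimate is 4500 nM, with a range from 1500 nM to 20000 nM, meaning an expected step of a 1.4-fold higher number from compound 3 to compound 4 (0.15 log units; within the scatter) that need not go beyond the scatter.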

Compound 4, half-maximal inhibitory concentration: 12800 nM
Estimate against measurement, compound 4: 2.8-fold (0.45 log units) below; measured number inside the range.
By their numbers in this assay, from the lowest: compounds 2 and 3 (each within the scatter of the next); then compound 4. At a limit, above all of these: compound 1.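

Within the data shown here, this is the first measured step on the anilino ring: with the 3,4,5-trimethoxyphenyl group kept, going from 4-chlorophenyl to 4-methoxyphenyl gives a 4.0-fold higher number from compound 3 to compound 4 (0.60 log units; beyond the scatter), so this position does move the number in this assay. With the 4-methoxyphenyl group held fixed, the aryl group on the shared core also matters, as 3,4,5-trimethoxyphenyl gives a 5.1-fold higher number from compound 2 to compound 4 (0.71 log units; beyond the scatter) and an at least 3.9-fold lower number from compound 1 to compound 4 (0.59 log units; beyond the scatter). That last step starts from compound 1, whose value is a limit of the assay, not a number: the limit of > 50000 nM in this assay, at which 1 of the 4 values shown sits.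

As far as these compounds go, a single pair carries the chloro-to-methoxy change, so whether it holds with 4-fluorophenyl or phenyl on the core stays open. Also open, from the compounds shown here alone, is how an amine or a carboxylic acid at this place on the anilino ring would read.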